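Methyl on the Sulfonyl Ring: Expected Effect in Compound 4

The source may report more compounds than this note shows. Statements on the series, on what has been measured and on what is new or still open speak of the compounds shown alone.

Measured compounds:
compound 1 `O=C(/C=C/c1ccc(Br)cc1)NS(=O)(=O)c1ccccc1` 3.9 ug/mL
compound 2 `Cc1ccc(S(=O)(=O)NC(=O)/C=C/c2ccc(Br)cc2)cc1` 12.1 ug/mL
compound 3 `CN(C)c1ccc(/C=C/C(=O)NS(=O)(=O)c2ccccc2)cc1` 2.3 ug/mL

All three were tested in a functional assay on B16-F10 cells (Mus musculus) for antiproliferative activity, read by ELISA and MTT assay, with a stated time of 48 h; on this read-out higher numbers stand for weaker inhibition and lower numbers for stronger inhibition. Compound 1 and compound 2 share a core and differ by methyl in place of hydrogen on an aromatic carbon; this change gave a 3.1-fold higher number from compound 1 to compound 2 (0.49 log units; beyond the scatter). Compound 1 and compound 3 differ by dimethylamino in place of bromo on an aromatic carbon, which gave a 1.7-fold lower number from compound 1 to compound 3 (0.23 log units; within the scatter). Compound 4 `Cc1ccc(S(=O)(=O)NC(=O)/C=C/c2ccc(N(C)C)cc2)cc1` has not yet been measured. Among the measured compounds shown here, it differs from compound 3 by methyl in place of hydrogen on an aromatic carbon, the same change as the one from compound 1 to compound 2, at the same place.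

For the measured compounds named here, with only one measured example of this change, the expectation for compound 4 rests on that single step. Going by the values given here, compound 4 is expected to show a 3.0-fold higher number from compound 3 to compound 4 (0.48 log units; beyond the scatter), because a 3.1-fold higher number from compound 1 to compound 2 (0.49 log units; beyond the scatter) is the only guide available. Compound 4 is therefore estimated at 7 ug/mL, within a range from 3 ug/mL to 16 ug/mL.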

Compound 4, half-maximal inhibitory concentration: 4.3 ug/mL
Beside the measured number, compound 4's estimate is 1.6-fold (0.21 log units) above it, and the stated range covers the measured number.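

In this assay, the change from phenyl to 4-methylphenyl on the core of compound 3 goes with a 1.9-fold higher number from compound 3 to compound 4 (0.27 log units; within the scatter), and this agrees with the earlier step: the same change on two cores in this assay, a 3.1-fold higher number (0.49 log units; beyond the scatter) from compound 1 to compound 2 and a 1.9-fold higher number (0.27 log units; within the scatter) from compound 3 to compound 4, 1.7-fold (0.22 log units) apart, within the scatter of two such steps. Dimethylamino in place of bromo, now on the methyl-bearing core, goes with a 2.8-fold lower number from compound 2 to compound 4 (0.45 log units; beyond the scatter), and this also agrees with its earlier counterpart: the same change on two cores in this assay, a 1.7-fold lower number (0.23 log units; within the scatter) from compound 1 to compound 3 and a 2.8-fold lower number (0.45 log units; beyond the scatter) from compound 2 to compound 4, 1.7-fold (0.22 log units) apart, within the scatter of two such steps. Among the compounds shown here, each change therefore carried over between these two cores, but this rests on only two pairs of steps and does not show that either change would behave the same way on any other core.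

From the compounds shown here alone, whether an ethyl group or a carboxylic acid in the methyl's place would follow the same trend remains open. So does whether an amine other than dimethylamino would match the steps seen here.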